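This account rests on a few compounds, and the source may have more. Where it says the series, first, only, none or still open, it means among the compounds named here.

Compound 1 `COc1cc2nc(C3CCC3)nc(N3CCN(c4ccccc4)CC3)c2cc1OC`, in an in vitro assay on U2OS cells for agonist activity at neurotensin receptor type 2 (Homo sapiens), read by reporter gene assay and beta-arrestin recruitment (a lower number here means that less compound is needed, a higher number that more compound is needed for the effect), compound 1 gives > 80000 nM.
Compound 2 `COc1cc2nc(C3CCC3)nc(N3CCN(c4ccccc4C)CC3)c2cc1OC`, in this assay compound 2 gives > 80000 nM.
Compound 3 `COc1cc2nc(C3CCC3)nc(N3CCN(c4ccccc4F)CC3)c2cc1OC`, in this assay compound 3 gives > 80000 nM.

Among the measured compounds shown here, the three compounds share one core and differ only in the single group on the six-membered aromatic ring of carbon only at the far end of the piperazine. The value of compound 1 is a limit of the assay and not a number. The value of compound 2 is likewise a limit. The value of compound 3 is also a limit. All three sit at the same place, (the limit of > 80000 nM in this assay, at which 3 of the 3 values shown sit), so compound 3 stands nowhere above or below its two companions; the steps a step that the two limits leave unreadable from compound 1 to compound 2, a step that the two limits leave unreadable from compound 1 to compound 3 and a step that the two limits leave unreadable from compound 2 to compound 3 cannot be read.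

Compound 4 `COc1cc2nc(C3CCC3)nc(N3CCN(c4ccccc4Cl)CC3)c2cc1OC` is the next member. It differs from compound 3 by chloro in place of fluoro on an aromatic carbon. For the measured compounds named here, no measured step bears on this change in a readable way, since hydrogen, methyl and fluoro at that place all left the assay at its limit. Compound 4 is therefore expected to behave like compound 3 and remain at the limit, with the step of a number no higher from compound 3 to compound 4 (the limit leaves the size open) expected to be none that can be read. The estimate for compound 4 is 80000 nM, spanning 30000 nM to 200000 nM.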

Compound 4, half-maximal effective concentration: > 80000 nM
Compound 4 ended at the assay's limit; the forecaster's own chance of this, stated with the estimate: 85%; the middle value sits exactly at the limit.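

Compound 4, like compound 1, compound 2 and compound 3, gives only a limit of the assay and not a number, so no step among these four compounds can be read: the limit of > 80000 nM in this assay, at which 4 of the 4 values shown sit.

The compounds shown leave open whether any other group on that ring, or any change elsewhere on the shared core, would give a readable number in this assay.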